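This account rests on a few compounds, and the source may have more. Where it says the series, first, only, none or still open, it means among the compounds named here.

Three compounds share the same core and differ mainly in the aryl group on the amine. Compound 2 `COc1ccc(/C=C/C(=O)Nc2cc3c(Nc4cc(Cl)cc(Cl)c4)ncnc3s2)cc1` gives the lowest of the three numbers in a functional assay on MDA-MB-231 cells (Homo sapiens) for antiproliferative activity, read by MTT assay, with a stated time of 48 h (a higher number here means a weaker inhibitor, a lower number a stronger inhibitor), at 1970 nM, though compound 1 lies within the scatter of it. Compound 1 `COc1ccc(/C=C/C(=O)Nc2cc3ncnc(Nc4ccc(F)c(Cl)c4)c3s2)cc1` gives 2600 nM in this assay. Compound 3 `O=C(/C=C/c1ccccc1)Nc1cc2c(Nc3cc(Cl)cc(Cl)c3)ncnc2s1` gives 11500 nM, and the step of a 5.8-fold higher number from compound 2 to compound 3 (0.77 log units; beyond the scatter) is the only one measured. Compound 4 `COc1ccc(/C=C/C(=O)Nc2cc3c(Nc4ccc(Cl)c(Cl)c4)ncnc3s2)cc1` differs from compound 2 by 3,4-dichlorophenyl in place of 3,5-dichlorophenyl on a nitrogen on an aromatic ring. Among the compounds with values here, no measured step exchanges chlorine positions on that ring. Since compound 1, carrying other halogens on that ring, gives 2600 nM, close to compound 2, a step within the scatter is expected, a 1.2-fold higher number from compound 2 to compound 4 (0.09 log units; within the scatter). Compound 4 is therefore estimated at 2400 nM, between 800 nM and 7500 nM.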

Compound 4, half-maximal inhibitory concentration: 16600 nM
For compound 4 the middle estimate is 6.9-fold (0.84 log units) below the measured one, and the stated range ends below it.
By their numbers in this assay, from the lowest: compounds 2 and 1 (each within the scatter of the next); then compounds 3 and 4 (each within the scatter of the next).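

In this assay, moving one chlorine so that 3,4-dichlorophenyl replaces 3,5-dichlorophenyl on the nitrogen gives an 8.4-fold higher number from compound 2 to compound 4 (0.93 log units; beyond the scatter). Within the data shown here, with the same atoms joined differently, the placement of the chlorines on this ring alone changes the number by more than the scatter, whereas the only earlier step concerned the methoxy group. Nothing available explains this shift.

The compounds shown leave open whether bromine or methyl groups in place of these chlorines would keep the number of compound 2. They also leave open whether the step recurs with hydrogen in place of methoxy.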